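Aryl substituent exchange at the ketone end of the series

The source may hold more compounds than are shown below. What is called first, only, known or untested is meant among the compounds shown, and "the series" means these compounds.

Compound 2 `O=C(/C=C/c1cc2ccccc2[nH]c1=O)c1ccc(O)cc1` gives 6870 nM in a functional assay on NCI-H460 cells (Homo sapiens) for cytotoxicity, read by sulforhodamine B assay, with a stated time of 24 h (on this read-out higher numbers stand for weaker inhibition of growth and lower numbers for stronger inhibition of growth), the lowest of the two numbers in hand; its nearest neighbour is compound 1 `COc1ccc(C(=O)/C=C/c2cc3ccccc3[nH]c2=O)cc1`, which in this assay gives 8340 nM. Within the data shown here, the only measured step, a 1.2-fold lower number from compound 1 to compound 2 (0.08 log units; within the scatter), covers hydrogen in place of methyl on an oxygen on an aromatic ring and stays within the scatter. Compound 3 `O=C(/C=C/c1cc2ccccc2[nH]c1=O)c1ccc(Cl)cc1` carries chloro in place of hydroxy on an aromatic carbon, on an aromatic carbon of a six-membered aromatic ring of carbon only, para to a large group; cut one bond further out, the change reads 4-hydroxyphenyl to 4-chlorophenyl. Among the measured compounds shown here, no measured step exchanges a hydroxy for a chloro, so the single step available bears on it only indirectly, and that step left the number within the scatter. For compound 3 no step beyond the scatter is therefore expected in this assay, in either direction, and the estimate is 6500 nM with a range from 2000 nM to 20000 nM, which means an expected step of a 1.1-fold lower number from compound 2 to compound 3 (0.02 log units; within the scatter).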

Compound 3, concentration for total growth inhibition: 18900 nM
Compound 3: the middle estimate sits 2.9-fold (0.46 log units) below what was measured, and the stated range covers the measured number.
By their numbers in this assay, from the lowest: compounds 2 and 1 (each within the scatter of the next); then compound 3.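

This position, para to a large group, is not indifferent to its substituent: in this assay, chloro in place of hydroxy gives a step beyond the scatter (a 2.8-fold higher number from compound 2 to compound 3 (0.44 log units; beyond the scatter)), whereas the hydroxy and methoxy pair showed none. Chloro in place of methoxy points the same way (a 2.3-fold higher number from compound 1 to compound 3 (0.36 log units; beyond the scatter)), so both oxygen-linked substituents stand apart from chloro, which gives the weaker inhibition of growth, although both steps are modest. Nothing available accounts for this shift.

A single chloro compound cannot show whether the step follows from removing the oxygen or from introducing chlorine. An amine, a fluoro or a methyl on the same aromatic carbon would help separate these two readings.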